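This account rests on a few compounds, and the source may have more. Where it says the series, first, only, none or still open, it means among the compounds named here.

In a functional assay on the whole organism (artery, strain albino) with Rattus norvegicus as the target, with a stated time of 300 min, at a dose of 10 mg/kg by the oral route (a lower number here means less inhibition, a higher number more inhibition at the dose given (going by the name of the read-out)), compound 1 `COc1ccc(C2N=C(SCc3cccc(Cl)c3)NC(C)=C2C(=O)Nc2ccc(F)cc2)cc1OC` gives 16.4%, while compound 2 `COc1ccc(C2N=C(SCc3ccc(Cl)cc3)NC(C)=C2C(=O)Nc2ccc(F)cc2)cc1OC` gives 31.3%. The two differ in one place, (4-chlorophenyl in place of 3-chlorophenyl on a saturated chain carbon bound to a sulfur), and the measured step is a number 14.9 percentage points higher from compound 1 to compound 2 (beyond the scatter). Compound 3 `CC1=C(C(=O)Nc2ccc([N+](=O)[O-])cc2)C(c2cccc([N+](=O)[O-])c2)N=C(SCc2cccc(Cl)c2)N1` is built on a different core, and how that core differs from the core of compound 1 is not broken down here. In this assay compound 3 gives 21%. Compound 4 `CC1=C(C(=O)Nc2ccc([N+](=O)[O-])cc2)C(c2cccc([N+](=O)[O-])c2)N=C(SCc2ccc(Cl)cc2)N1` is related to compound 3 by the same change, (4-chlorophenyl in place of 3-chlorophenyl on a saturated chain carbon bound to a sulfur), made at the same place. That change has been measured once, as the step of a number 14.9 percentage points higher from compound 1 to compound 2 (beyond the scatter), so a rise of similar size is expected, a number 13 percentage points higher from compound 3 to compound 4 (beyond the scatter), though the different core leaves room for a smaller gain. Compound 4 is therefore estimated to give 34% in this assay, with a likely range from 19% to 49%.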

Compound 4, a percentage reported as inhibition, in the whole organism at one dose (the size of the read-out at that dose, not a potency): 24.1%
Compound 4: middle estimate off by 9.9 percentage points, on the high side; measured number inside the range.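

On the core of compound 3, 4-chlorophenyl in place of 3-chlorophenyl gives a number 3.1 percentage points higher from compound 3 to compound 4 (within the scatter), so on this core the change brings no clear gain. Set beside the step on the core of compound 1, the two results cannot be told apart: the same change on two cores in this assay, a number 14.9 percentage points higher (beyond the scatter) from compound 1 to compound 2 and a number 3.1 percentage points higher (within the scatter) from compound 3 to compound 4, 11.8 percentage points apart, within the scatter of two such steps. For the compounds shown here, this does not show that the change carries over fully from one core to the other, nor that the core alters its effect, as each core offers only one pair.

From the compounds shown here alone, what happens with other groups in place of the chlorophenyl, such as a plain phenyl, a methoxyphenyl or a carboxylic acid, remains open. Also open, going by these compounds, is whether either core would respond the same way to those groups.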